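Trading morpholin-4-yl for methylamino on compound 1

The source may hold more compounds than are shown below. What is called first, only, known or untested is meant among the compounds shown, and "the series" means these compounds.

Of the compounds shown here, three have numbers so far in an in vitro ADME assay on microsomes from liver (Homo sapiens) for metabolic stability; a lower number here means slower removal, a higher number faster removal of the compound. Compound 1 (`CC[C@H](C)[C@@H]1C(=O)N[C@H](C2Cc3ccccc3C2)C(=O)N1[C@@H](C(=O)N1CCOCC1)c1cnc(C)cc1C`) gives 1 mL.min-1.g-1, the lowest of the three. Compound 3 (`CC[C@H](C)[C@@H]1C(=O)N[C@H](C2Cc3ccccc3C2)C(=O)N1[C@@H](C(=O)N(C)C)c1ccc(C)nc1C`) gives 7 mL.min-1.g-1 and compound 2 (`CCC(CC)[C@@H]1C(=O)N[C@H](C2Cc3ccccc3C2)C(=O)N1[C@@H](C(=O)N1CCOCC1)c1ccc(C)nc1`) gives 12 mL.min-1.g-1. Both numbers lie beyond the usual scatter from compound 1, but each of these compounds differs from compound 1 in more than one place, so neither isolates a single change.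

Compound 4 (`CC[C@H](C)[C@@H]1C(=O)N[C@H](C2Cc3ccccc3C2)C(=O)N1[C@@H](C(=O)NC)c1cnc(C)cc1C`) keeps the core of compound 1 and alters one group: methylamino in place of morpholin-4-yl on a carbonyl carbon. In words, methylamino stands in place of morpholin-4-yl on a carbonyl carbon.

Going by the values given here, no measured pair shows this change alone, so any forecast is uncertain. Compound 3 also lacks morpholin-4-yl and gives 7 mL.min-1.g-1, which hints at a small rise in this assay, though it differs elsewhere too. The expected change is a 2.5-fold higher number from compound 1 to compound 4 (0.40 log units; beyond the scatter). For compound 4 the estimated value is 2.5 mL.min-1.g-1, with an expected range of 1 mL.min-1.g-1 to 7 mL.min-1.g-1.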

Compound 4, intrinsic clearance in microsomes: 7 mL.min-1.g-1
Estimate against measurement, compound 4: 2.8-fold (0.45 log units) below; low and high end bracket the measured number.
By their numbers in this assay, from the lowest: compound 1; then compounds 3, 4 and 2 (each within the scatter of the next).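

Going by these compounds alone, compound 1 and compound 4 form the first pair here that differs in one place only. In this assay, the change at this carbonyl carbon gives a 7.0-fold higher number from compound 1 to compound 4 (0.85 log units; beyond the scatter), which shows that this group alone can shift the number beyond the usual scatter. The step is modest, and it swaps a six-membered non-aromatic ring for a small chain that carries a hydrogen-bond donor, so the low number of compound 1 depends at least partly on what sits at this position. Nothing measured here explains the rise.

This single pair cannot separate the loss of the ring from the gain of the donor. Piperidin-1-yl, a ring without the oxygen, or ethylamino, a longer chain on the nitrogen, would each test one of these differences on the core of compound 1.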